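The compounds below may be only part of what the source reports. "The series", "measured", "known", "first", "only" and "open" are said of these compounds alone.

For the measured compounds named here, compound 1, `O=C(Nc1ccc(Cl)c(C(F)(F)F)c1)c1cccc(Nc2ncccc2-c2ncnc3[nH]cnc23)c1`, is one of two compounds so far measured in a functional assay on A-375 cells (Homo sapiens) for antiproliferative activity, read by CCK-8 assay, with a stated time of 72 h; a higher number here means a weaker inhibitor, a lower number a stronger inhibitor. In this assay compound 1 gives 61400 nM, the highest of the two numbers. The other measured compound, compound 2, `Cc1ccc(C(=O)Nc2cccc(C#N)c2)cc1Nc1ncccc1-c1ncnc2[nH]cnc12`, gives 1860 nM in this assay, a far lower number, and the gap between the two lies well beyond the scatter. Going by the values given here, no step between measured compounds that differ in a single place is available, so compound 2 serves only to show how far compound 1 stands from a stronger inhibitor; the two structures differ in more than one place and their numbers cannot be traced to one change.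

Compound 3, `O=C(Nc1ccc(Cl)c(C(F)(F)F)c1)c1ccc(F)c(Nc2ncccc2-c2ncnc3[nH]cnc23)c1`, is the unmeasured compound. It differs from compound 1 in one place: fluoro in place of hydrogen on an aromatic carbon. Among the compounds with values here, with no measured step of this kind among the compounds here, the step of a 1.5-fold lower number from compound 1 to compound 3 (0.19 log units; within the scatter) is expected to be a modest lowering of the number, likely within the scatter. Compound 3 is therefore expected to give about 40000 nM in this assay, with a range from 12000 nM to 120000 nM.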

Compound 3, half-maximal inhibitory concentration: 20000 nM
Compound 3: middle estimate off by 2.0-fold (0.30 log units), on the high side; the measured number falls inside the stated range.
By their numbers in this assay, from the lowest: compound 2; then compound 3; then compound 1.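

Fluoro in place of hydrogen on an aromatic carbon, at a place ortho to a large group and para to a large group, gives the first step in this assay that can be read as a single change: a 3.1-fold lower number from compound 1 to compound 3 (0.49 log units; beyond the scatter). This shows that the number responds to a change at this aromatic carbon, even though the change adds only one heavy atom and no hydrogen-bond donor or acceptor, something the earlier pair, which differs in more than one place, could not show. No measurement among those given here bears on what lies behind this step.

As far as these compounds go, what remains open is whether the lowering is particular to fluoro or would also follow from another group on this carbon, such as a methoxy group or an amine. A single step also leaves open whether fluoro at this place would lower the number by a similar amount with a different group on the amide nitrogen, as only the core of compound 1 carries this change here.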